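A Methoxy Group Added to a Long-Chain Amide Series

The source may hold more compounds than are shown below. What is called first, only, known or untested is meant among the compounds shown, and "the series" means these compounds.

Three long-chain amides have been tested in a functional assay with Rattus norvegicus as the target; a higher number here means that more compound is needed for the effect, a lower number that less compound is needed. Compound 1 `CCCCCCCCC(=O)NCc1cc(OC)c(O)cc1OC` gives only a limit of the assay, > 100000 nM. Compound 2 `CCCCCCCCC(=O)NCc1ccc(O)cc1OC` likewise gives only a limit, > 100000 nM. For the measured compounds named here, compound 3 `CCCCCCCCC(=O)NCc1ccncc1` is the one member with a measured number, giving 28000 nM in this assay.

Compound 1 differs from compound 2 by methoxy in place of hydrogen on an aromatic carbon. The step that the two limits leave unreadable from compound 2 to compound 1 cannot be read, since both values sit at the limit of > 100000 nM in this assay, at which 2 of the 3 values shown sit.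

Compound 4 `CCCCCCCCC(=O)NCc1ccnc(OC)c1` has not yet been measured. It differs from compound 3 by methoxy in place of hydrogen on an aromatic carbon. This is the same kind of change as that from compound 2 to compound 1, but the surroundings differ: in compound 1 the new group sits ortho to a hydroxy group and para to a methoxy group on a ring of carbon only, while in compound 4 it sits next to the ring nitrogen. The difference between the cores of compound 2 and compound 3 is not broken down here.

Going by the values given here, the only measured step that the two limits leave unreadable from compound 2 to compound 1 has no readable size, so the expectation for compound 4 rests on compound 3 alone, which gives 28000 nM. Compound 4 is expected to come in near 40000 nM, spanning 10000 nM to 150000 nM. The step of a 1.4-fold higher number from compound 3 to compound 4 (0.15 log units; within the scatter) is expected to stay within the usual scatter.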

Compound 4, half-maximal effective concentration: 31500 nM
For compound 4 the middle estimate is 1.3-fold (0.10 log units) above the measured one; low and high end bracket the measured number.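

In this assay the new step is a 1.1-fold higher number from compound 3 to compound 4 (0.05 log units; within the scatter), so on the core of compound 3, methoxy in place of hydrogen next to the ring nitrogen gives two compounds that cannot be told apart. For the compounds shown here, this is the first readable size for this change, but it cannot be set against the same change on the other core, as the step from compound 2 to compound 1 cannot be read: the limit of > 100000 nM in this assay, at which 2 of the 4 values shown sit. Carrying the change from one core to another therefore remains untested here, and a single step on a single core gives no rule for the series.

The compounds shown leave open how an amine or a carboxylic acid would read at the same place on the core of compound 3, and whether methoxy elsewhere on that ring would match compound 4. Also open, from the compounds shown here alone, is what a longer chain on the amide would do to the number of compound 4 in this assay.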